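The compounds below may be only part of what the source reports. "The series", "measured", "known", "first", "only" and "open" are said of these compounds alone.

Working notes on the series. Within the data shown here, compound 1 `CCN(CC)S(=O)(=O)c1ccc(S(=O)(=O)N2CCC[C@@H](C(=O)N3CCC(OC)CC3)C2)cc1` gives 1420 nM in a functional assay on BXPC-3 cells (Homo sapiens) for inhibition, read by MTT assay, with a stated time of 7 days (on this read-out higher numbers stand for weaker inhibition and lower numbers for stronger inhibition), the highest of the three numbers measured so far. Compound 2 `CCN(CC)C(=O)c1ccc(S(=O)(=O)N2CCC[C@@H](C(=O)N3CCC(F)(F)CC3)C2)cc1` gives 240 nM in this assay, and compound 3 `O=C([C@@H]1CCCN(S(=O)(=O)c2ccc(S(=O)(=O)C3CC3)cc2)C1)N1CCC(F)(F)CC1` gives 129 nM. Among the measured compounds shown here, the only single-point step measured, a 1.9-fold lower number from compound 2 to compound 3 (0.27 log units; within the scatter), concerns the group on the aromatic carbon, not the amide side of the core.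

Compound 4 `CCN(CC)S(=O)(=O)c1ccc(S(=O)(=O)N2CCC[C@@H](C(=O)N[C@@H]3CCOC3)C2)cc1` differs from compound 1 at the amide: (oxolan-3-yl)amino in place of 4-methoxypiperidin-1-yl on a carbonyl carbon. For the measured compounds named here, no measured pair isolates this change. Compounds 2 and 3 carry a different amide substituent from compound 1, but they also differ from it on the aromatic carbon, so their lower numbers cannot be assigned to the amide alone. With nothing bearing directly on this swap, the expected step is a 1.1-fold higher number from compound 1 to compound 4 (0.02 log units; within the scatter), a move not distinguishable from the scatter, with wide uncertainty around it. Compound 4 is accordingly estimated at 1500 nM in this assay, with a range from 400 nM to 6000 nM.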

Compound 4, half-maximal inhibitory concentration: 2270 nM
Compound 4: the middle estimate sits 1.5-fold (0.18 log units) below what was measured; the range from low to high includes it.
By their numbers in this assay, from the lowest: compounds 3 and 2 (each within the scatter of the next); then compounds 1 and 4 (each within the scatter of the next).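

In this assay, among these compounds, the step of a 1.6-fold higher number from compound 1 to compound 4 (0.20 log units; within the scatter) gives the first single-change reading on the amide side of the shared core. On this carbonyl carbon, replacing the six-membered 4-methoxypiperidin-1-yl ring with the five-membered (oxolan-3-yl)amino group, which adds a hydrogen-bond donor and a defined stereocentre, produces no difference that can be told from the scatter. No supporting evidence bears on this result, so it stays a bare observation for this one pair.

Going by these compounds, it remains open what a morpholin-4-yl or dimethylamino group would give on the same carbonyl carbon with the rest of compound 1 unchanged. Also open, on these data alone, are the effects of a methyl group in place of the amide hydrogen of compound 4 and of the opposite configuration at its oxolan-3-yl stereocentre.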